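The source may hold more compounds than are shown below. What is called first, only, known or untested is meant among the compounds shown, and "the series" means these compounds.

Of the compounds shown here, two from this series have been measured so far. Compound 1, `CNc1nc(-c2ccccc2)nc2c1nnn2Cc1ccccc1F`, carries a methylamino group on the shared core and a 2-fluorobenzyl group; in an assay on Cerebral cortex for displacement of a labelled ligand from adenosine receptor A1 (Bos taurus) (on this read-out higher numbers stand for weaker inhibition and lower numbers for stronger inhibition), compound 1 gives 25 nM. Compound 2, `CCCCCCNc1nc(-c2ccccc2)nc2c1nnn2Cc1ccccc1`, carries a hexylamino group in place of the methylamino group and a plain benzyl group; in this assay compound 2 gives 13.2 nM. Of the two numbers recorded, compound 2 has the lowest, yet the number for compound 1 falls within the usual scatter of repeated measurements, so the two compounds cannot be told apart on this evidence.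

Compound 3, `CCCCCCNc1nc(-c2ccccc2)nc2c1nnn2Cc1ccccc1F`, has not yet been measured. It differs from compound 2 in one place only: fluoro in place of hydrogen on an aromatic carbon. Going by the values given here, no measured pair in this set isolates that change, so nothing here tells its size directly. Given how close compound 1 and compound 2 already sit, the step from compound 2 to compound 3 is expected to stay within the scatter, a 1.2-fold lower number from compound 2 to compound 3 (0.08 log units; within the scatter), with no clear direction. Compound 3 is therefore estimated at 11 nM, in a range from 4 nM to 35 nM.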

Compound 3, inhibition constant: 25 nM
Beside the measured number, compound 3's estimate is 2.3-fold (0.36 log units) below it; the measured number falls inside the stated range.
By their numbers in this assay, from the lowest: compounds 2, 1 and 3 (each within the scatter of the next).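

In this assay, the change of fluoro in place of hydrogen on an aromatic carbon, ortho to a large group, can now be read on its own, and it comes to a 1.9-fold higher number from compound 2 to compound 3 (0.28 log units; within the scatter); with the hexylamino group held constant, the benzyl and 2-fluorobenzyl groups therefore cannot be told apart. The chain can now be read on its own as well: with the 2-fluorobenzyl group held constant, pentyl in place of hydrogen on a saturated chain carbon bound to a nitrogen on an aromatic ring gives no change at the digits printed from compound 1 to compound 3 (within the scatter), so the methylamino and hexylamino groups cannot be told apart in this pair either. Nothing available explains either step, and these small steps give no firm sign that one group is better than the other.

The compounds shown leave open whether a larger group, such as chloro or methoxy, in place of the fluoro would give a step beyond the scatter. They also leave open what a branched chain, a cyclohexylamino group or a free amine would do in place of the hexylamino group.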